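The source may hold more compounds than are shown below. What is called first, only, known or untested is meant among the compounds shown, and "the series" means these compounds.

Values in a functional assay on the whole organism with Mus musculus as the target; a lower number here means that less compound is needed, a higher number that more compound is needed for the effect:
- compound 1 `CCn1nc(-c2ccc(Cl)cc2)n(C)c1=S`: > 50 mg/kg, a limit
- compound 2 `COc1ccc(-c2nn(C)c(=S)n2C)cc1`: > 25 mg/kg, a limit
- compound 3 `Cn1nc(-c2ccc(Cl)cc2)n(C)c1=S`: 1.34 mg/kg

Among the measured compounds shown here, compound 3 holds the only actual number in this set, and the other two entries are limits. Compound 4 `Cn1nc(-c2ccccc2)n(C)c1=S` has hydrogen in place of chloro on an aromatic carbon. The closest evidence is an at least 18-fold lower number from compound 2 to compound 3 (1.27 log units; beyond the scatter), a large step at the same carbon, though it involves methoxy rather than hydrogen. The step of an at least 37-fold lower number from compound 1 to compound 3 (1.57 log units; beyond the scatter) lies elsewhere in the structure and does not bear on this change. Losing the chloro is therefore expected to raise the number in this assay, but by less than the methoxy step. The expected change is a 4.5-fold higher number from compound 3 to compound 4 (0.65 log units; beyond the scatter). For compound 4 the estimated value is 6 mg/kg, with an expected range of 1.5 mg/kg to 25 mg/kg.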

Compound 4, dose for half-maximal effect: 0.15 mg/kg
Estimate against measurement, compound 4: 40-fold (1.60 log units) above; measured number below the stated range.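

At this aromatic carbon, hydrogen outperforms chloro in this assay, with an 8.9-fold lower number from compound 3 to compound 4 (0.95 log units; beyond the scatter). Chloro is therefore not required for the effect, and the best of the three substituents shown here is no substituent at all. Replacing methoxy with hydrogen gives an at least 160-fold lower number from compound 2 to compound 4 (2.22 log units; beyond the scatter), but this step is open-ended, as compound 2 is only a limit: the limit of > 25 mg/kg in this assay, at which 1 of the 4 values shown sits.

Still open, as far as these compounds go, is whether fluoro or methyl at this carbon would match hydrogen. Also open, from the compounds shown here alone, is whether hydrogen there would hold up alongside the ethyl chain of compound 1.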